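The source may hold more compounds than are shown below. What is called first, only, known or untested is meant among the compounds shown, and "the series" means these compounds.

In a physicochemical assay for solubility, read by HPLC, using the shake flask method, with a stated time of 2 h, at pH 2 (a higher number here means a more soluble compound, a lower number a less soluble compound), three compounds have been measured:

- Compound 1 `Nc1ncc(-c2ccc(C(=O)N3CCC(O)C3)cc2)nc1-c1ccc(C(F)(F)F)cc1`: 129000 nM
- Compound 2 `Nc1ncc(-c2ccc(C(=O)N3CC[C@@H](O)C3)cc2)nc1-c1ccc(C(F)(F)F)cc1`: 103000 nM
- Compound 3 `Nc1ncc(-c2ccc(C(=O)N3CCC(O)CC3)cc2)nc1-c1ccc(C(F)(F)F)cc1`: 119000 nM

Compound 3 lies within the scatter of both other compounds, so the three values set up no order. The next compound, compound 4 `Nc1ncc(-c2ccc(C(=O)N3CCC(N)C3)cc2)nc1-c1ccc(C(F)(F)F)cc1`, carries 3-aminopyrrolidin-1-yl in place of 4-hydroxypiperidin-1-yl on a carbonyl carbon.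

Two measured steps exchange these ring sizes, with the hydroxy group kept. They are a 1.1-fold lower number from compound 1 to compound 3 (0.04 log units; within the scatter) and a 1.2-fold higher number from compound 2 to compound 3 (0.06 log units; within the scatter), and both are small and within the scatter. The step of a 1.3-fold lower number from compound 1 to compound 2 (0.10 log units; within the scatter) is equally small. Within the data shown here, no measured step exchanges a hydroxy group for an amino group, so that part of the change remains untested in this assay. No step beyond the scatter is therefore expected, although the estimated range is left wider on the upper side. The expected change is a 1.3-fold higher number from compound 3 to compound 4 (0.10 log units; within the scatter). For compound 4, the estimated value is 150000 nM, with an expected range from 90000 nM to 300000 nM.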

Compound 4, solubility: 165000 nM
For compound 4 the middle estimate is 1.1-fold (0.04 log units) below the measured one; low and high end bracket the measured number.
By their numbers in this assay, from the lowest: compounds 2, 3, 1 and 4 (each within the scatter of the next).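

In this assay the exchange of hydroxy for amino on a saturated ring carbon can now be read directly, and it gives a 1.3-fold higher number from compound 1 to compound 4 (0.11 log units; within the scatter) as its step. The same exchange with a defined configuration in the starting compound gives a 1.6-fold higher number from compound 2 to compound 4 (0.20 log units; within the scatter) and the exchange combined with the change of ring size gives a 1.4-fold higher number from compound 3 to compound 4 (0.14 log units; within the scatter) so on this carbonyl carbon neither the amino group nor the combined change takes a compound beyond the scatter of the others. Nothing available here bears on why these steps are so small.

The compounds shown leave open whether a dimethylamino group or a carboxylic acid on the same pyrrolidine ring would also stay within the scatter of these four compounds. They also leave open whether a defined configuration at the amino-bearing carbon of compound 4 would do so.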